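The source may hold more compounds than are shown below. What is called first, only, known or untested is meant among the compounds shown, and "the series" means these compounds.

Measured so far in a functional assay on B16-F10 cells (Mus musculus) for inhibition, read by MTT assay, with a stated time of 72 h; a higher number here means a weaker inhibitor, a lower number a stronger inhibitor:
compound 1 `CC(C)c1ccc(-c2nc(SCc3cn(CC(=O)NC(=O)Nc4ccccn4)nn3)nc(Nc3ccc(F)cc3)c2C#N)cc1` — 7250 nM
compound 2 `CC(C)c1ccc(-c2nc(SCc3cn(CC(=O)NC(=O)Nc4ccccn4)nn3)nc(Nc3cccc(C(F)(F)F)c3)c2C#N)cc1` — 1700 nM
compound 3 `Cc1ccc(Nc2nc(SCc3cn(CC(=O)NC(=O)Nc4ccccn4)nn3)nc(-c3ccc(C(C)C)cc3)c2C#N)cc1` — 3060 nM

Compound 3 stands second highest of the three numbers. Against compound 2 its gap is within the scatter (a 1.8-fold higher number from compound 2 to compound 3 (0.26 log units; within the scatter)); against compound 1 it is beyond it (a 2.4-fold lower number from compound 1 to compound 3 (0.37 log units; beyond the scatter)).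

Compound 4 `Cc1ccc(Nc2nc(SCc3cn(CC(=O)NC(=O)Nc4ccccn4)nn3)nc(-c3ccc(C)cc3)c2C#N)cc1` differs from compound 3 by methyl in place of isopropyl on an aromatic carbon. Among the measured compounds shown here, none of the measured steps touches this position: a 4.3-fold lower number from compound 1 to compound 2 (0.63 log units; beyond the scatter) and a 2.4-fold lower number from compound 1 to compound 3 (0.37 log units; beyond the scatter) both concern the aryl on the nitrogen. For the measured compounds named here, no step therefore bears on the change, and no direction can be read from the data; a step within the scatter is the working expectation in this assay, with a wide range to allow a modest move either way.

Compound 4 is estimated at 3800 nM, range 1400 nM to 11000 nM, an expected step of a 1.2-fold higher number from compound 3 to compound 4 (0.09 log units; within the scatter).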

Compound 4, half-maximal inhibitory concentration: 1010 nM
Compound 4: the middle estimate sits 3.8-fold (0.58 log units) above what was measured; the measured number lies below the stated range.
By their numbers in this assay, from the lowest: compounds 4, 2 and 3 (each within the scatter of the next, the first and the last beyond it); then compound 1.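

The position carrying the 4-isopropylphenyl group is not silent in this assay: trimming it to 4-methylphenyl gives a 3.0-fold lower number from compound 3 to compound 4 (0.48 log units; beyond the scatter), so the larger group is not needed for the lower number. Among the compounds shown here, this is the first measured change at this aryl, and it is seen only with 4-methylphenyl on the nitrogen. No measurement at hand accounts for the step.

As far as these compounds go, whether the step carries over to the 3-(trifluoromethyl)phenyl or 4-fluorophenyl compounds remains open. So does the reading with hydrogen, methoxy or a dimethylamino group on this aromatic carbon.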